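The compounds below may be only part of what the source reports. "The series", "measured", "known", "first", "only" and "open" are said of these compounds alone.

In a functional assay on Chem-3 cells for antagonist activity at metabotropic glutamate receptor 1 (Homo sapiens), read by fluorescence and calcium flux (on this read-out lower numbers stand for stronger inhibition and higher numbers for weaker inhibition), compound 1 `N#Cc1c(NCc2ccccc2)sc2c1CCN(C(=O)c1ccn[nH]1)C2` gives 1090 nM and compound 2 `N#Cc1c(NCc2ccc(F)cc2)sc2c1CCN(C(=O)c1ccn[nH]1)C2` gives 2030 nM. Compound 2 differs from compound 1 by fluoro in place of hydrogen on an aromatic carbon, and this gave a 1.9-fold higher number from compound 1 to compound 2 (0.27 log units; within the scatter). Compound 3 `N#Cc1c(NCc2cccc(F)c2)sc2c1CCN(C(=O)c1ccccc1)C2` gives 5310 nM in this assay, the highest number of the three measured compounds; the difference between the core of compound 3 and the core of compound 1 is not broken down here. Compound 4 `N#Cc1c(NCc2cccc(F)c2)sc2c1CCN(C(=O)c1ccc(F)cc1)C2` has not yet been measured. It differs from compound 3 by fluoro in place of hydrogen on an aromatic carbon, the same kind of change as between compound 1 and compound 2, though here it sits on the benzoyl group rather than on the benzyl group. Because the earlier step of a 1.9-fold higher number from compound 1 to compound 2 (0.27 log units; within the scatter) was small, the step of a 1.4-fold higher number from compound 3 to compound 4 (0.15 log units; within the scatter) is expected to be of similar size. Compound 4 is therefore estimated at 7500 nM in this assay, roughly between 3500 nM and 16000 nM.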

Compound 4, half-maximal inhibitory concentration: 2380 nM
For compound 4 the middle estimate is 3.2-fold (0.50 log units) above the measured one; the measured number lies below the stated range.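

In this assay there is a 2.2-fold lower number from compound 3 to compound 4 (0.35 log units; beyond the scatter) when fluoro replaces hydrogen on the benzoyl group. Set beside the earlier step, the same kind of change did not carry over unchanged from one core to the other: the same change on two cores in this assay, a 1.9-fold higher number (0.27 log units; within the scatter) from compound 1 to compound 2 and a 2.2-fold lower number (0.35 log units; beyond the scatter) from compound 3 to compound 4, 4.2-fold (0.62 log units) apart, beyond the scatter of two such steps. So the size and direction of this step on one core cannot simply be assumed on another in this series. For the compounds shown here, with only two pairs, however, and with the fluoro on a different group in each, this does not show whether the core or the place of the fluoro sets the outcome.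

Still open, on these data alone, is what a chlorine atom, a methoxy group or an amine would do in place of that fluoro on the benzoyl group.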